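Swapping a Furan for a Methylphenyl on the Shared Core

A few compounds are considered here, and "the series" means these few. Any claim that something is new, unique, unknown or untested is made for them only; others in the source may bear on it.

Two compounds built on the same core have been examined so far. Compound 1 `Cc1c(Br)sc(N)c1C(=O)c1ccc(Cl)cc1` carries a bromine on the five-membered ring, while compound 2 `CC(C)(C)Cc1c(-c2ccoc2)sc(N)c1C(=O)c1ccc(Cl)cc1` carries a furan-3-yl ring and a neopentyl group in the corresponding positions. In an assay on CHO cells for displacement of a labelled ligand from adenosine receptor A3 (Homo sapiens), read by scintillation counting, tested at 10 uM (a lower number here means less inhibition, a higher number more inhibition at the concentration tested (going by the name of the read-out)), compound 1 gives 1%, and in this assay compound 2 gives 1%. Compound 2 thus stands level with compound 1 at the digits reported, the two values lying within the usual scatter of such measurements; neither shows meaningful displacement of the labelled ligand at the concentration tested.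

Compound 3 `Cc1ccccc1-c1sc(N)c(C(=O)c2ccc(Cl)cc2)c1CC(C)(C)C` is the next candidate. Compared with compound 2, the change is 2-methylphenyl in place of furan-3-yl on an aromatic carbon. The furan-3-yl ring leaves and a 2-methylphenyl ring enters, on the aromatic carbon next to the ring sulfur and next to the ring atom that bears the neopentyl group.

Within the data shown here, no comparison between measured compounds covers such a change, so the expectation rests on the two values already in hand. Since compound 1 and compound 2 both sit near the bottom of the scale, the expected step from compound 2 to compound 3 is a number 2 percentage points higher from compound 2 to compound 3 (within the scatter), that is, nothing beyond the scatter. Compound 3 is therefore estimated at 3%, with a likely range from -8% to 18%.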

Compound 3, a percentage reported as inhibition, at one concentration (the size of the read-out at that concentration, not a potency): 1%
Beside the measured number, compound 3's estimate is 2 percentage points above it, and the stated range covers the measured number.
By their numbers in this assay, from the lowest: compounds 1, 2 and 3 (each within the scatter of the next).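

In this assay the aromatic carbon next to the ring sulfur now has its first direct comparison between two rings: 2-methylphenyl in place of furan-3-yl gives no change at the digits printed from compound 2 to compound 3 (within the scatter) and so leaves the reading at the bottom of the scale. The exchange removes a five-membered aromatic ring with 1 hetero atom and 1 hydrogen-bond acceptor and brings in a six-membered aromatic ring of carbon only, yet neither compound shows meaningful displacement of the labelled ligand at the concentration tested. Nothing measured here explains this outcome, and with both readings so low, this pair cannot show whether the position matters at all.

Still open, going by these compounds, is how an amine, a carboxylic acid or a longer alkyl chain on this same carbon would read in this assay. Also open, on these data alone, is whether a change to the neopentyl group or the amino group on the shared core would lift the number clear of the bottom of the scale.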